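Swapping a hydroxycyclohexylmethyl urea for a hydroxypyrrolidine

A few compounds are considered here, and "the series" means these few. Any claim that something is new, unique, unknown or untested is made for them only; others in the source may bear on it.

Three ureas built on one shared core have been measured in an assay on HEK293 cells for displacement of a labelled ligand from melanin-concentrating hormone receptor 1 (Homo sapiens); on this read-out lower numbers stand for stronger inhibition and higher numbers for weaker inhibition. Compound 1 `O=C(NC1CCN(Cc2ccn(-c3ccc(C(F)(F)F)cc3)c2)CC1)N1CC[C@H](O)C1` gives 125 nM, compound 2 `O=C(NC1CCN(Cc2ccn(-c3ccc(C(F)(F)F)cc3)c2)CC1)N1CCCC1Cc1cccnc1` gives 26 nM, and compound 3 `O=C(NC[C@H]1CCCC[C@H]1O)NC1CCN(Cc2ccn(-c3ccc(C(F)(F)F)cc3)c2)CC1` gives 63 nM, the second highest of the three numbers; its nearest neighbour is compound 1 and its furthest is compound 2, with a 2.4-fold higher number from compound 2 to compound 3 (0.38 log units; beyond the scatter). Compound 4 `O=C(NC1CCN(Cc2ccn(-c3ccc(C(F)(F)F)cc3)c2)CC1)N1CC[C@@H](O)C1` differs from compound 3 by 3-hydroxypyrrolidin-1-yl in place of ((2-hydroxycyclohexyl)methyl)amino on a carbonyl carbon, and carries the same group as compound 1 in the mirror form at its stereocentre. The closest measured guide is the reverse exchange, a 2.0-fold lower number from compound 1 to compound 3 (0.30 log units; within the scatter), which was small. The step from compound 3 to compound 4 is therefore expected to be a 1.7-fold higher number from compound 3 to compound 4 (0.24 log units; within the scatter). In this assay compound 4 is estimated at 110 nM, within 45 nM to 300 nM.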

Compound 4, half-maximal inhibitory concentration: 138 nM
Compound 4: middle estimate off by 1.3-fold (0.10 log units), on the low side; the measured number falls inside the stated range.
By their numbers in this assay, from the lowest: compound 2; then compounds 3, 1 and 4 (each within the scatter of the next, the first and the last beyond it).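

In this assay the mirror form of the 3-hydroxypyrrolidin-1-yl group shows no difference that stands out from the scatter, with a 1.1-fold higher number from compound 1 to compound 4 (0.04 log units; within the scatter), and this comparison is a clean one: the fact that compounds 1 and 4 differ only in the configuration as drawn. Exchanging ((2-hydroxycyclohexyl)methyl)amino for this mirror form gives a 2.2-fold higher number from compound 3 to compound 4 (0.34 log units; beyond the scatter), which clears the scatter, whereas the same exchange with the other form did not. The widest gap remains a 5.3-fold higher number from compound 2 to compound 4 (0.72 log units; beyond the scatter), leaving 2-((pyridin-3-yl)methyl)pyrrolidin-1-yl with the lowest number of the four.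

On these data alone, what a plain pyrrolidin-1-yl group, without the hydroxyl, would give on this carbonyl carbon stays open. So does the part played by the pyridine nitrogen, which a phenyl ring in its place would test.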